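Swapping 2-chlorophenyl for 1,3,4-thiadiazol-2-yl on a sulfonamide nitrogen

The source may report more compounds than this note shows. Statements on the series, on what has been measured and on what is new or still open speak of the compounds shown alone.

In a functional assay on RAW264.7 cells (Mus musculus) for inhibition (on this read-out higher numbers stand for weaker inhibition and lower numbers for stronger inhibition), compound 1 (`CCOC(=O)C1=CCCCC1S(=O)(=O)Nc1ccccc1`) gives 260 nM while compound 2 (`CCOC(=O)C1=CCCCC1S(=O)(=O)Nc1ccccc1Cl`) gives 12 nM and compound 3 (`CCOC(=O)C1=CCCCC1S(=O)(=O)Nc1ccc(C#N)cc1Cl`) gives 1600 nM here, which leaves compound 2 with the lowest of the three numbers. Compound 4 (`CCOC(=O)C1=CCCCC1S(=O)(=O)Nc1nncs1`) carries 1,3,4-thiadiazol-2-yl in place of 2-chlorophenyl on a sulfonamide nitrogen. Among the compounds with values here, no measured step makes this replacement. The nearest are a 22-fold lower number from compound 1 to compound 2 (1.34 log units; beyond the scatter) with chloro in place of hydrogen and a 130-fold higher number from compound 2 to compound 3 (2.12 log units; beyond the scatter) with cyano in place of hydrogen on an aromatic carbon, both large. With compound 2 at 12 nM as the low end of the series, a large rise is expected in this assay rather than a step within the scatter. The expected change is a 67-fold higher number from compound 2 to compound 4 (1.82 log units; beyond the scatter) as an estimate. Compound 4 is estimated at 800 nM with an expected range from 80 nM to 8000 nM in this measurement.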

Compound 4, half-maximal inhibitory concentration: > 10000 nM
Compound 4: only a limit was reported (the forecaster's own chance of this, stated with the estimate: 15%); middle value at least 12-fold (1.09 log units) away from the limit.
By their numbers in this assay, from the lowest: compound 2; then compound 1; then compound 3. At a limit, above all of these: compound 4.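

In this assay compound 4 gives > 10000 nM, which is a limit of the assay and not a number. Exchanging the whole aromatic ring on the sulfonamide nitrogen gives an at least 830-fold higher number from compound 2 to compound 4 (2.92 log units; beyond the scatter), and set against the unsubstituted ring it gives an at least 38-fold higher number from compound 1 to compound 4 (1.58 log units; beyond the scatter). The earlier compounds shown here varied only substituents on a six-membered ring of carbon, whereas these steps show that the ring itself matters at this position, with or without the chloro group. The compounds shown leave open whether a thiophene or a pyridine on the sulfonamide nitrogen would stay near compound 2 or rise as compound 4 does.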